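This account rests on a few compounds, and the source may have more. Where it says the series, first, only, none or still open, it means among the compounds named here.

Measured so far in an ADME assay on SH-SY5Y cells (Homo sapiens) for cytotoxicity, read by MTT assay, with a stated time of 72 h; a lower number here means a stronger inhibitor, a higher number a weaker inhibitor:
- compound 1 `O=C(CN1CCN(C(=O)c2cccc(Br)c2)CC1)N1CCN(CCCc2c[nH]c3ccccc23)CC1`: 80500 nM
- compound 2 `O=C(CN1CCN(C(=O)c2ccccc2F)CC1)N1CCN(CCCc2c[nH]c3ccccc23)CC1`: 82600 nM

Among the compounds with values here, compound 1 and compound 2 cannot be told apart in this assay; the step of a 1.0-fold higher number from compound 1 to compound 2 (0.01 log units; within the scatter) lies within the scatter, so compound 1 stands at a number that the one other measured compound simply shares.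

Compound 3 `O=C(CN1CCN(C(=O)c2cccc(Br)c2)CC1)N1CCN(CCCc2c[nH]c3ccc(F)cc23)CC1` differs from compound 1 by fluoro in place of hydrogen on an aromatic carbon. Within the data shown here, no measured step touches this part of the shared core: the only step on record, from compound 1 to compound 2, swaps the group on the carbonyl carbon at the other end of the molecule and produced no movement beyond the scatter. The series therefore gives no reason to expect a step in this assay from a single fluoro added on the indole ring, in either direction.

Compound 3 is expected to give about 80000 nM in this assay, with a range of 40000 nM to 160000 nM, meaning an expected step of a 1.0-fold lower number from compound 1 to compound 3 (0.00 log units; within the scatter) that stays within the scatter.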

Compound 3, half-maximal inhibitory concentration: 71600 nM
Beside the measured number, compound 3's estimate is 1.1-fold (0.05 log units) above it; low and high end bracket the measured number.
By their numbers in this assay, from the lowest: compounds 3, 1 and 2 (each within the scatter of the next).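

Replacing hydrogen with fluoro on this aromatic carbon, which turns 1H-indol-3-yl into 5-fluoro-1H-indol-3-yl, gives in this assay a step of a 1.1-fold lower number from compound 1 to compound 3 (0.05 log units; within the scatter) and so produces no distinguishable difference. The series now has one change at each end of the molecule, since the carbonyl end gave a 1.0-fold higher number from compound 1 to compound 2 (0.01 log units; within the scatter) and compounds 1, 2 and 3 cannot be told apart in this read-out. No measurement on hand bears on why the values stay together.

Going by these compounds, whether a group other than fluoro on the same aromatic carbon, such as methoxy or an amine, would give a step beyond the scatter remains open. So does whether a longer chain between the indole and the shared core would leave the number where it stands.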